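The compounds below may be only part of what the source reports. "The series", "measured", "known", "first", "only" and "open" are said of these compounds alone.

Among the compounds with values here, compound 3 `CC1=CCC[C@](C)(CC/C(C)=C/CC2=C(O)C(=O)C=C(NCC(=O)O)C2=O)[C@@H]1C` is the one compound here with a numerical result in an ADME assay on KB cells (Homo sapiens) for cytotoxicity, with a stated time of 48 h (on this read-out higher numbers stand for weaker inhibition and lower numbers for stronger inhibition), where compound 3 gives 5.4 ug/mL. The other two results are limits of the assay rather than numbers. Compound 1 `C=C1[C@H](C)CCC[C@]1(C)CC/C(C)=C/CC1=C(O)C(=O)C=C(N[C@H](C(=O)O)C(C)C)C1=O` reaches only a limit in this assay, giving > 10 ug/mL. Compound 2 `C=C1[C@H](C)CCC[C@]1(C)CC/C(C)=C/CC1=C(O)C(=O)C=C(N[C@@H](C(=O)O)[C@@H](C)O)C1=O` likewise sits at a limit in this assay, giving > 10 ug/mL. The step that the two limits leave unreadable from compound 1 to compound 2 is therefore not readable as a size, a point captured by the limit of > 10 ug/mL in this assay, at which 2 of the 3 values shown sit.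

Compound 4 `CC1=CCC[C@](C)(CC/C(C)=C/CC2=C(O)C(=O)C=C(N[C@H](CO)C(=O)O)C2=O)[C@@H]1C` differs from compound 3 by hydroxymethyl in place of hydrogen on a saturated chain carbon bound to an amine nitrogen and a carbonyl carbon. No measured step among these compounds reports a readable size for adding a group on this carbon, since the only change of the amine substituent, from compound 1 to compound 2, runs between two limits. What the numbers do show is that the two compounds carrying a larger substituent on the amine nitrogen sit at the limit, while compound 3, carrying only carboxymethyl, gives a number. On that basis compound 4 is expected to move toward weaker inhibition by roughly a 1.5-fold higher number from compound 3 to compound 4 (0.17 log units; within the scatter), an expectation that is modest and uncertain. Compound 4 is thus estimated at 8 ug/mL, within a range from 4 ug/mL to 20 ug/mL.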

Compound 4, half-maximal inhibitory concentration: > 10 ug/mL
Compound 4: a limit, no number; the forecaster's own chance of this, stated with the estimate: 40%; middle value at least 1.2-fold (0.09 log units) away from the limit.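

Hydroxymethyl in place of hydrogen on a saturated chain carbon bound to an amine nitrogen and a carbonyl carbon gives an at least 1.8-fold higher number from compound 3 to compound 4 (0.26 log units; that floor lies within the scatter), the first step at this position with a readable size, though it is readable only as a floor. On these data alone, the full size stays unknown, since compound 4 reaches a limit and not a number, so this result does not separate the change from the scatter. Compound 3 remains the only compound with a number in this assay, and compound 4 joins the others at the limit: the limit of > 10 ug/mL in this assay, at which 3 of the 4 values shown sit.

The compounds shown leave open whether a methyl group on this carbon, which adds the carbon without the oxygen, would still give a number in this assay. They also leave open how a primary amide in place of the carboxylic acid would read on the carboxymethyl of compound 3.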